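This account rests on a few compounds, and the source may have more. Where it says the series, first, only, none or still open, it means among the compounds named here.

Measured so far:
- compound 1, `CCN(CC)CCNC(=O)c1ccc(C(CC)(CC)c2ccc(OCS(=O)(=O)c3ccccc3)c(C)c2)n1CC`: 7130 nM
- compound 2, `CCn1c(C(=O)N[C@H](CO)CCO)ccc1C(CC)(CC)c1ccc(OCS(=O)(=O)c2ccccc2)c(C)c1`: 12100 nM

In a functional assay on PC-3 cells (Homo sapiens) for antiproliferative activity, read by MTT assay, with a stated time of 24 h (on this read-out higher numbers stand for weaker inhibition and lower numbers for stronger inhibition), compound 1 gives 7130 nM, the lowest of the two numbers seen; the nearest is compound 2, and the step of a 1.7-fold higher number from compound 1 to compound 2 (0.23 log units; within the scatter) stays within the scatter, so the two cannot be told apart on this read-out.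

Compound 3, `CCn1c(C(=O)N[C@H](CO)CCCO)ccc1C(CC)(CC)c1ccc(OCS(=O)(=O)c2ccccc2)c(C)c1`, has not yet been measured. It differs from compound 1 by a group of 7 heavy atoms (5 carbon, 2 oxygen; no ring) in place of a group of 7 heavy atoms (6 carbon, 1 nitrogen; no ring), on an amide-type nitrogen. Going by the values given here, the only measured step that bears on this change is the one from compound 1 to compound 2, where the same group left the amide-type nitrogen and a group of the same kind as in compound 3 entered; that step, a 1.7-fold higher number from compound 1 to compound 2 (0.23 log units; within the scatter), was within the scatter. Among the compounds with values here, compound 3 carries one more carbon in its chain than compound 2, but no step between those two has been measured, so only their values will show what that adds.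

Compound 3 is therefore expected to sit close to compound 1, with the expected step of a 1.5-fold higher number from compound 1 to compound 3 (0.19 log units; within the scatter) lying within the scatter. The estimate for compound 3 in this assay is 11000 nM, with a range from 5000 nM to 25000 nM.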

Compound 3, half-maximal inhibitory concentration: 6810 nM
For compound 3 the middle estimate is 1.6-fold (0.21 log units) above the measured one, and the stated range covers the measured number.
By their numbers in this assay, from the lowest: compounds 3, 1 and 2 (each within the scatter of the next).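

In this assay, the step of a 1.0-fold lower number from compound 1 to compound 3 (0.02 log units; within the scatter) shows that the amide-type nitrogen can carry a group of 5 carbon and 2 oxygen atoms in place of 2-(diethylamino)ethyl with no change that can be told apart on this read-out; the basic-looking amine of compound 1 is thus not needed to keep its number, at least among these compounds. Going by these compounds alone, putting hydroxymethyl in place of hydroxy on the saturated chain carbon gives the first direct look at chain length here, and a 1.8-fold lower number from compound 2 to compound 3 (0.25 log units; within the scatter) stays within the scatter as well, so all three groups on this nitrogen give numbers that cannot be separated. No measurement is available that would explain this flat result.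

The compounds shown leave open whether any group on this nitrogen can move the number beyond the scatter, since all three values lie within it of one another. A carboxylic acid, a primary amine or a much longer chain at this place could answer that, and the same question stands for changes elsewhere on the shared core.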